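The source may hold more compounds than are shown below. What is called first, only, known or untested is meant among the compounds shown, and "the series" means these compounds.

In a functional assay on HL-60 cells (Homo sapiens) for cytotoxicity, read by XTT assay, with a stated time of 3 days (a lower number here means a stronger inhibitor, a higher number a weaker inhibitor), three related compounds have been measured so far. Compound 1 `OC[C@H]1O[C@@H](n2cc(F)c3c(-c4ccoc4)ncnc32)[C@H](O)[C@@H]1O` gives 2000 nM, compound 2 `OC[C@H]1O[C@@H](n2cc(Cl)c3c(-c4ccco4)ncnc32)[C@H](O)[C@@H]1O` gives 21600 nM, and compound 3 `OC[C@H]1O[C@@H](n2cc(Cl)c3c(-c4cccs4)ncnc32)[C@H](O)[C@@H]1O` gives 5500 nM, which places compound 3 in the middle of the three. The next compound, compound 4 `OC[C@H]1O[C@@H](n2cc(Cl)c3c(-c4ccoc4)ncnc32)[C@H](O)[C@@H]1O`, changes a single group: furan-3-yl in place of thiophen-2-yl on an aromatic carbon. In words, furan-3-yl stands in place of thiophen-2-yl on an aromatic carbon.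

Among the compounds with values here, the only measured step at this place is a 3.9-fold lower number from compound 2 to compound 3 (0.59 log units; beyond the scatter), a modest change on replacing furan-2-yl with thiophen-2-yl. It shows that the group here can move the number, but it involves a different furan. Compound 1 already carries furan-3-yl, with fluorine where compound 4 has chlorine, and compound 1 gives 2000 nM. Within the data shown here, no measured step isolates that difference, so this is only a rough guide. A modest move towards a lower number therefore seems likely. The expected step is a 1.8-fold lower number from compound 3 to compound 4 (0.26 log units; within the scatter). For compound 4, the estimated value is 3000 nM, with an expected range of 800 nM to 11000 nM.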

Compound 4, half-maximal inhibitory concentration: 2500 nM
Compound 4: the middle estimate sits 1.2-fold (0.08 log units) above what was measured; low and high end bracket the measured number.
By their numbers in this assay, from the lowest: compounds 1 and 4 (each within the scatter of the next); then compound 3; then compound 2.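

In this assay, furan-3-yl in place of furan-2-yl gives an 8.6-fold lower number from compound 2 to compound 4 (0.94 log units; beyond the scatter), so the two furans, which differ only in how the ring is attached, are far from interchangeable here. Furan-3-yl also beats thiophen-2-yl, with a 2.2-fold lower number from compound 3 to compound 4 (0.34 log units; beyond the scatter), a step beyond the scatter that the earlier compounds could not show. Chloro in place of fluoro gives a 1.3-fold higher number from compound 1 to compound 4 (0.10 log units; within the scatter), which stays within the scatter, so with furan-3-yl on the shared core the two halogens cannot be told apart in this assay.

Going by these compounds, it remains open how thiophen-3-yl, an amine or a longer chain would behave on this aromatic carbon, and whether the halogens stay this close with furan-2-yl or thiophen-2-yl. No measurement shown here explains these differences.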